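From propyl to cyclopropylmethyl in compound 3

The source may report more compounds than this note shows. Statements on the series, on what has been measured and on what is new or still open speak of the compounds shown alone.

In an ADME assay on Caco-2 cells (Homo sapiens) for permeability, read by LC-MS, with a stated time of 2 h (on this read-out higher numbers stand for higher permeability and lower numbers for lower permeability), compound 1 (`Cc1cc(CN(CC2CC2)C(CC(=O)O)c2ccc(Cl)cc2)ccc1OCCn1c(=O)ccn(C)c1=O`) gives 3.7 nm/s and compound 2 (`CCCN(Cc1ccc(OCCn2c(=O)ccn(C)c2=O)c(OC)c1)C(CC(=O)O)c1ccc(Cl)cc1`) gives 1 nm/s as the lower number of the two, a gap beyond the usual scatter. Compound 3 (`COc1cc(CN(CC2CC2)C(CC(=O)O)c2ccc(Cl)cc2)ccc1OCCn1c(=O)ccn(C)c1=O`) has not yet been measured. It departs from compound 2 by a single change (cyclopropyl in place of ethyl on a saturated chain carbon bound to an amine nitrogen) with cyclopropyl in place of ethyl on a saturated chain carbon bound to an amine nitrogen, which can also be read as propyl to cyclopropylmethyl. Among the compounds with values here, no measured pair shows this change on its own, so the expectation is a loose one. Within the data shown here, with compound 1 at 3.7 nm/s as the only higher number, a small rise within the scatter is expected in this assay for this change. The expected move a 1.8-fold higher number from compound 2 to compound 3 (0.26 log units; within the scatter) is small. The estimate for compound 3 is 1.8 nm/s with 0.7 nm/s to 4.5 nm/s as the expected range.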

Compound 3, apparent permeability: 0.8 nm/s
The estimate for compound 3 lay 2.3-fold (0.35 log units) above the measured number, within the range that was stated.
By their numbers in this assay, from the lowest: compounds 3 and 2 (each within the scatter of the next); then compound 1.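

With the methoxy group held in place, cyclopropyl in place of ethyl on a saturated chain carbon bound to an amine nitrogen gives a 1.3-fold lower number from compound 2 to compound 3 (0.10 log units; within the scatter) in this assay, so this change on its own does not separate compound 2 and compound 3. With cyclopropyl held in place, methoxy in place of methyl on an aromatic carbon gives a 4.6-fold lower number from compound 1 to compound 3 (0.67 log units; beyond the scatter), which makes the aromatic carbon, and not the chain carbon, the place where a single change is seen to go beyond the scatter. Still open, from the compounds shown here alone, is whether an ethoxy group or a fluorine on that aromatic carbon would give a step of similar size, and whether a longer chain on the saturated chain carbon would stand apart from ethyl and cyclopropyl. No measurement at hand offers a reason for either step.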